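Piperazine in Place of a Bridged Diamine on the Shared Core

A few compounds are considered here, and "the series" means these few. Any claim that something is new, unique, unknown or untested is made for them only; others in the source may bear on it.

Measured compounds:
compound 1, `C[C@@H]1CN(c2cccc3c2C[C@H](CN(C)[C@H]2CCCc4cccnc42)NC3)C[C@H](C)N1`, 61 nM
compound 2, `CN(C[C@H]1Cc2c(cccc2N2CCN3CCC[C@@H]3C2)CN1)[C@H]1CCCc2cccnc21`, 3.59 nM
compound 3, `CN(C[C@H]1Cc2c(cccc2N2C[C@H]3C[C@@H]2CN3)CN1)[C@H]1CCCc2cccnc21`, 20.7 nM

In a functional assay on CCRF-CEM cells for antagonist activity at C-X-C chemokine receptor type 4 (Homo sapiens), read by calcium flux, with stated times of 25 min and 90 s (on this read-out higher numbers stand for weaker inhibition and lower numbers for stronger inhibition), compound 3 stands second highest of the three numbers. Its nearest neighbour is compound 1, and the step of a 2.9-fold lower number from compound 1 to compound 3 (0.47 log units; beyond the scatter) is modest; its furthest is compound 2, and the step of a 5.8-fold higher number from compound 2 to compound 3 (0.76 log units; beyond the scatter) is modest as well. The largest step in the set, a 17-fold lower number from compound 1 to compound 2 (1.23 log units; beyond the scatter), separates the two groups that flank compound 3.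

Compound 4, `CN(C[C@H]1Cc2c(cccc2N2CCNCC2)CN1)[C@H]1CCCc2cccnc21`, differs from compound 3 in one place: a group of 6 heavy atoms (4 carbon, 2 nitrogen; one six-membered non-aromatic ring with 2 hetero atoms) in place of a group of 7 heavy atoms (5 carbon, 2 nitrogen; 2 five-membered non-aromatic rings with 1 hetero atom each), on an aromatic carbon. The group that enters is a six-membered ring with two hetero atoms, as in compound 1, but without the methyl groups of compound 1, and the count of one hydrogen-bond donor and two hydrogen-bond acceptors is the same as for the group that leaves.

Within the data shown here, two measured steps bear on this change. Compound 1, carrying a six-membered ring with two hetero atoms, gave a modestly higher number than compound 3. Compound 2, with its fused five- and six-membered ring pair, gave the lowest number. A return to a single six-membered ring is therefore expected to give a modestly higher number in this assay, a 1.9-fold higher number from compound 3 to compound 4 (0.29 log units; within the scatter), and compound 4 is estimated at 40 nM, within 15 nM to 120 nM.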

Compound 4, half-maximal inhibitory concentration: 6.08 nM
Estimate against measurement, compound 4: 6.6-fold (0.82 log units) above; measured number outside the range, below it.
By their numbers in this assay, from the lowest: compounds 2 and 4 (each within the scatter of the next); then compound 3; then compound 1.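

In this assay, among these compounds, the one change confined to the methyl groups is a 10-fold lower number from compound 1 to compound 4 (1.00 log units; beyond the scatter), with piperazin-1-yl in place of 3,5-dimethylpiperazin-1-yl on the aromatic carbon, so the high number of compound 1 goes with those methyl groups and not with the six-membered ring itself. The unsubstituted ring also alters how the other groups compare: a 3.4-fold lower number from compound 3 to compound 4 (0.53 log units; beyond the scatter) favours piperazin-1-yl over the group with two five-membered rings, while a 1.7-fold higher number from compound 2 to compound 4 (0.23 log units; within the scatter) lies within the scatter, so piperazin-1-yl and the fused five- and six-membered ring pair cannot be told apart on this read-out. Nothing available explains why these groups differ.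

The compounds shown leave open whether a single methyl group on the piperazine ring would already raise the number, since the only methylated ring here carries both methyl groups. They also leave open whether the ring nitrogen that carries the hydrogen is needed at all, a question that morpholin-4-yl, with an oxygen atom in its place, would address on the same shared core.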